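The source may report more compounds than this note shows. Statements on the series, on what has been measured and on what is new or still open speak of the compounds shown alone.

Measured so far in an assay on CHO cells for antagonist activity at transient receptor potential cation channel subfamily V member 1 (Homo sapiens), read by FLIPR; a higher number here means a weaker inhibitor, a lower number a stronger inhibitor:
compound 1, `CCCN(CCC)c1cc(C(F)(F)F)ccc1CNC(=O)C(C)c1ccc(NS(C)(=O)=O)c(F)c1` — 0.3 nM
compound 2, `CCCCSc1cc(C(F)(F)F)ccc1CNC(=O)C(C)c1ccc(NS(C)(=O)=O)c(F)c1` — 1.9 nM

Compound 2 stands at the higher of the two numbers in this assay; its nearest neighbour is compound 1, with the step of a 6.3-fold higher number from compound 1 to compound 2 (0.80 log units; beyond the scatter), which is beyond the scatter. Both compounds share the same core and differ only in the group on the aromatic carbon that bears the dipropylamino or butylsulfanyl.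

The unmeasured compound 3, `CC(C(=O)NCc1ccc(C(F)(F)F)cc1Cl)c1ccc(NS(C)(=O)=O)c(F)c1`, follows from compound 2 by one change: chloro in place of butylsulfanyl on an aromatic carbon

Among the measured compounds shown here, only one measured step bears on this, a 6.3-fold higher number from compound 1 to compound 2 (0.80 log units; beyond the scatter), and it concerns the same position, yet it exchanges one chain-bearing group for another, not a chain-bearing group for a single chlorine. It shows that this position moves the number beyond the scatter, and the direction seen there is toward weaker inhibition as dipropylamino gives way to butylsulfanyl. For the measured compounds named here, no measured pair shows a chloro at this place, so the size of the step for compound 3 is uncertain.

Compound 3 is expected to give a higher number than compound 2, the estimated step being a 7.9-fold higher number from compound 2 to compound 3 (0.90 log units; beyond the scatter). The estimate for compound 3 in this assay is 15 nM, within a range of 3 nM to 80 nM.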

Compound 3, inhibition constant: 4 nM
The estimate for compound 3 lay 3.8-fold (0.57 log units) above the measured number; the range from low to high includes it.
By their numbers in this assay, from the lowest: compound 1; then compound 2; then compound 3.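

In this assay, cutting this substituent from butylsulfanyl (5 heavy atoms) to chloro (1 heavy atom) gives a 2.1-fold higher number from compound 2 to compound 3 (0.32 log units; beyond the scatter) and stays a modest step, so the chain of compound 2 is not required for a strong inhibitor at this place, ortho to a large group and meta to a trifluoromethyl group. Measured against the dipropylamino group, the same chloro gives a 13-fold higher number from compound 1 to compound 3 (1.12 log units; beyond the scatter) as a large step, so the three compounds now order this position as dipropylamino, then butylsulfanyl, then chloro, from the lowest number to the highest. No supporting data accompany these numbers to account for that order.

Still open, from the compounds shown here alone, is whether the order follows the atom attached to the ring or the chains it carries: a butoxy group would change the linking atom while keeping the butyl chain, and a dimethylamino group would keep the nitrogen with shorter chains. Also open, going by these compounds, is how far the number moves with a fluoro or a plain hydrogen here, and whether a cyclic amine such as piperidine matches dipropylamino.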